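The source may report more compounds than this note shows. Statements on the series, on what has been measured and on what is new or still open speak of the compounds shown alone.

Working notes on the series. Compound 1 `COc1cc(/C=N/c2c(C#N)ncn2-c2ccc(F)cc2)cc(OC)c1OC` gives 8320 nM in a functional assay on MCF7 cells (Homo sapiens) for antiproliferative activity, read by MTT assay, with a stated time of 48 h; on this read-out higher numbers stand for weaker inhibition and lower numbers for stronger inhibition. Compound 2 `COc1ccc(OC)c(/C=N/c2c(C#N)ncn2-c2ccc(F)cc2)c1` gives 7090 nM in this assay. Compound 3 `N#Cc1ncn(-c2ccc(F)cc2)c1/N=C/c1ccc([N+](=O)[O-])cc1` gives 9100 nM in this assay. Going by the values given here, the values of compound 3, compound 1 and compound 2 all sit within the usual scatter of one another, so nothing separates the three on this read-out; the series so far is uniformly weak. Compound 4 `COc1ccc(/C=N/c2c(C#N)ncn2-c2ccc(F)cc2)cc1` is not yet measured. It differs from compound 3 by methoxy in place of nitro on an aromatic carbon. Among the compounds with values here, with no measured step to draw on and the three known values all alike, no change beyond the scatter is expected: the step from compound 3 to compound 4 is estimated at a 1.1-fold lower number from compound 3 to compound 4 (0.06 log units; within the scatter). Compound 4 is expected to give about 8000 nM in this assay, within 3500 nM to 18000 nM.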

Compound 4, half-maximal inhibitory concentration: 9330 nM
For compound 4 the middle estimate is 1.2-fold (0.07 log units) below the measured one, and the stated range covers the measured number.
By their numbers in this assay, from the lowest: compounds 2, 1, 3 and 4 (each within the scatter of the next).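

In this assay, methoxy in place of nitro on an aromatic carbon, para to a large group, gives a 1.0-fold higher number from compound 3 to compound 4 (0.01 log units; within the scatter). Going by these compounds alone, this is the only step read so far at this position, and it stays within the scatter even though the two groups differ in atoms and in hydrogen-bond acceptors. The read-out therefore does not separate these two groups here, and nothing measured speaks to the reason. As far as these compounds go, it remains open whether an amine or a carboxylic acid on this aromatic carbon would move the number beyond the scatter. From the compounds shown here alone, whether changes elsewhere on the shared core would do so is equally open.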